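Return of a hydrogen-bond donor: expectations for compound 3

The source may report more compounds than this note shows. Statements on the series, on what has been measured and on what is new or still open speak of the compounds shown alone.

Compound 1 `CC(CNC1CCCC1)Oc1cccc2ccc(N)nc12` gives 30 nM in a functional assay on IMR-32 cells with melanin-concentrating hormone receptor 1 (Homo sapiens) as the target, read by fluorescence; on this read-out lower numbers stand for stronger inhibition and higher numbers for weaker inhibition.
Compound 2 `CC(CN1CCCC1)Oc1cccc2ccc(N)nc12` gives 360 nM in this assay.

Among the compounds with values here, compound 2 stands highest of the two numbers; its only neighbour is compound 1, separated by a 12-fold higher number from compound 1 to compound 2 (1.08 log units; beyond the scatter). Compound 3 `CC(CNCc1ccsc1)Oc1cccc2ccc(N)nc12` differs from compound 2 by ((thiophen-3-yl)methyl)amino in place of pyrrolidin-1-yl on a saturated chain carbon, two bonds along the chain from an oxygen on an aromatic ring. Within the data shown here, the single measured step, a 12-fold higher number from compound 1 to compound 2 (1.08 log units; beyond the scatter), accompanied the loss of the hydrogen-bond donor that the counted change now restores, so a drop in number back towards compound 1 is expected, though the new group is larger than either earlier one. Compound 3 is estimated at 60 nM, with a range from 20 nM to 200 nM. The expected step is a 6.0-fold lower number from compound 2 to compound 3 (0.78 log units; beyond the scatter).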

Compound 3, half-maximal inhibitory concentration: 150 nM
Compound 3: middle estimate off by 2.5-fold (0.40 log units), on the low side; measured number inside the range.
By their numbers in this assay, from the lowest: compound 1; then compound 3; then compound 2.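

With the amine hydrogen back on the chain, the change from pyrrolidin-1-yl to ((thiophen-3-yl)methyl)amino gives a 2.4-fold lower number from compound 2 to compound 3 (0.38 log units; beyond the scatter) in this assay. Holding a hydrogen-bond donor at this place is therefore not enough to match compound 1, since the group on the amine nitrogen still matters, with (thiophen-3-yl)methyl in place of cyclopentyl giving a 5.0-fold higher number from compound 1 to compound 3 (0.70 log units; beyond the scatter) as the result. No accompanying evidence accounts for either step. The compounds shown leave open how a cyclohexyl or a benzyl group on the amine nitrogen would compare with cyclopentyl and (thiophen-3-yl)methyl. They also leave open whether a longer chain between the amine nitrogen and the thiophene ring would move the number towards that of compound 1.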